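Cytotoxicity of Amide Variants on a Shared Diol Core

The source may report more compounds than this note shows. Statements on the series, on what has been measured and on what is new or still open speak of the compounds shown alone.

Compound 1, `COC(=O)/C=C/[C@H]1C[C@@H](O)[C@@H](O)C1`, gives > 350000 nM in an ADME assay on S2 cells (Drosophila melanogaster) for cytotoxicity, read by MTT assay (on this read-out lower numbers stand for an effect already at smaller amounts and higher numbers for an effect only at larger amounts of compound), which is a limit of the assay and not a number.
Compound 2, `CNC(=O)/C=C/[C@H]1C[C@@H](O)[C@@H](O)C1`, gives > 250000 nM in this assay, likewise a limit.
Compound 3, `CCCCNC(=O)/C=C/[C@H]1C[C@@H](O)[C@@H](O)C1`, gives > 250000 nM in this assay, also a limit.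

Compound 3 therefore stands at the limit shared by the limit of > 250000 nM in this assay, at which 2 of the 3 values shown sit, with the limit of > 350000 nM in this assay, at which 1 of the 3 values shown sits, sitting close by. The steps a step that the two limits leave unreadable from compound 1 to compound 2, a step that the two limits leave unreadable from compound 1 to compound 3 and a step that the two limits leave unreadable from compound 2 to compound 3 cannot be read. Compound 4, `O=C(/C=C/[C@H]1C[C@@H](O)[C@@H](O)C1)NC1CC1`, differs from compound 3 by cyclopropyl in place of butyl on an amide-type nitrogen. Going by the values given here, no measured step gives its size or direction, so no change beyond the scatter is expected in this assay, and the result will most likely again be a limit. Compound 4 is estimated at 300000 nM, within 100000 nM to 700000 nM, a step that the limit leaves unreadable from compound 3 to compound 4 that is expected, not known.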

Compound 4, half-maximal effective concentration: > 250000 nM
Compound 4 ended at the assay's limit; the forecaster's own chance of this, stated with the estimate: 85%; the middle value does not contradict the limit.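

Compound 4, like compound 1, compound 2 and compound 3, gives only a limit in this assay, so no step among these compounds can be read. The compounds shown leave open at what concentration any of them affects these cells.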